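Indolyl in place of fluorophenyl on the enaminone amine nitrogen

The source may report more compounds than this note shows. Statements on the series, on what has been measured and on what is new or still open speak of the compounds shown alone.

The series shares the core of compound 1 `O=C(/C=C\Nc1ccc(F)cc1)c1nc(-c2ccc(F)cc2)n2ccccc12`. In a functional assay on B16-F10 cells (Mus musculus) for cytotoxicity, read by MTT assay, with a stated time of 48 h (a lower number here means a stronger inhibitor, a higher number a weaker inhibitor), compound 1 gives > 30000 nM, which is a limit of the assay and not a number. Compound 3 `O=C(/C=C\Nc1ccc(F)cc1)c1nc(-c2ccc(C(F)(F)F)cc2)n2ccccc12` also sits at a limit, > 30000 nM. Compound 2 `O=C(/C=C\Nc1ccc2cc[nH]c2c1)c1nc(-c2ccc(C(F)(F)F)cc2)n2ccccc12` likewise gives only a limit, > 30000 nM. Hence the step that the two limits leave unreadable from compound 1 to compound 3 and the step that the two limits leave unreadable from compound 2 to compound 3 cannot be read, as the limit of > 30000 nM in this assay, at which 3 of the 3 values shown sit, records. Compound 4 `Cc1cc2cc(N/C=C\C(=O)c3nc(-c4ccc(F)cc4)n4ccccc34)ccc2[nH]1` differs from compound 1 by 2-methyl-1H-indol-5-yl in place of 4-fluorophenyl on an amine nitrogen. Going by the values given here, no measured step bears directly on this change; compound 2, which also carries an indolyl group on the amine nitrogen, shows only a limit, so no shift beyond the scatter is readable. Compound 4 is expected to give 25000 nM (range 4000 nM to 60000 nM), a step of an at least 1.2-fold lower number from compound 1 to compound 4 (0.07 log units; that floor lies within the scatter) that will probably again be reported as a limit.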

Compound 4, half-maximal inhibitory concentration: > 30000 nM
Compound 4: no number, only a limit; the forecaster's own chance of this, stated with the estimate: 60%; middle value at least 1.2-fold (0.07 log units) from the limit.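

Compound 4, like compound 1, gives only a limit in this assay, so the step between them cannot be read: the limit of > 30000 nM in this assay, at which 4 of the 4 values shown sit.

From the compounds shown here alone, whether any change to the shared core gives a readable number remains open.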